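Pyrrolidin-3-yl amide on the shared core: expected response

A few compounds are considered here, and "the series" means these few. Any claim that something is new, unique, unknown or untested is made for them only; others in the source may bear on it.

Compound 1 `Cc1nc(-c2ccc(C(F)(F)F)cc2)sc1CNc1ccc(CCCC(=O)O)cc1` and compound 2 `Cc1nc(-c2ccc(C(F)(F)F)cc2)sc1CNc1ccc([C@H]2C[C@@H]2C(=O)N[C@H](C)c2ccccc2)cc1` share one core and differ only in the chain on the phenyl ring. In a functional assay on CHO cells for agonist activity at Free fatty acid receptor 1 (Homo sapiens), read by a luciferase reporter (a higher number here means a larger maximal response, a lower number a smaller maximal response), compound 1 gives 44%. In this assay compound 2 gives 42%; this is the lower of the two numbers, but the gap to compound 1 is within the scatter, so no order between them can be read. Compound 3 `Cc1nc(-c2ccc(C(F)(F)F)cc2)sc1CNc1ccc([C@H]2C[C@@H]2C(=O)NC2CCNC2)cc1` is not yet measured. It differs from compound 2 in one place: pyrrolidin-3-yl in place of 1-phenylethyl on an amide-type nitrogen. For the measured compounds named here, no step between measured compounds is known, so the size of this change has no direct precedent here; the only hint is that two rather different chains gave the same response. A step of compound 2 to compound 3 is therefore expected to stay within the scatter, with a number 2 percentage points lower from compound 2 to compound 3 (within the scatter). Compound 3 is expected to give about 40% in this assay, with a range from 22% to 58%.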

Compound 3, largest response reached (reported as percent of maximum), in percent of the reference or control that the assay uses: 52%
The estimate for compound 3 lay 12 percentage points below the measured number; the measured number falls inside the stated range.
By their numbers in this assay, from the lowest: compounds 2, 1 and 3 (each within the scatter of the next).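

In this assay pyrrolidin-3-yl in place of 1-phenylethyl on the amide-type nitrogen gives a number 10 percentage points higher from compound 2 to compound 3 (within the scatter) and so shows that this position accepts both a carbon-only aromatic ring and a non-aromatic ring with a hetero atom without a readable change in maximal response. The wider exchange of 3-carboxypropyl for 2-((pyrrolidin-3-yl)carbamoyl)cyclopropyl on the aromatic carbon gives a number 8 percentage points higher from compound 1 to compound 3 (within the scatter) and likewise leaves the carboxylic acid chain and this amide chain unseparated. Nothing available bears on why these responses stay together.

On these data alone, whether any group on this nitrogen moves the response beyond the scatter stays open. A longer chain ending in a primary amine there, or a carboxylic acid directly on the cyclopropyl ring in place of the amide, would test how far this insensitivity extends.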